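The source may hold more compounds than are shown below. What is called first, only, known or untested is meant among the compounds shown, and "the series" means these compounds.

Measured so far in an assay on HEK293 cells for antagonist activity at P2X purinoceptor 7 (Homo sapiens), read by fluorescence, with a stated time of 2 h; a lower number here means a stronger inhibitor, a higher number a weaker inhibitor:
compound 1 `COc1ccc(C(=O)N2CCC(n3cncc3-c3ccc(OS(=O)(=O)c4cccc5cnccc45)cc3)CC2)cc1`, 77 nM
compound 2 `CCN(CC)c1ccc(C(=O)N2CCC(n3cncc3-c3ccc(OS(=O)(=O)c4cccc5cnccc45)cc3)CC2)cc1`, 1440 nM
compound 3 `CC(C)(O)c1ccc(C(=O)N2CCC(n3cncc3-c3ccc(OS(=O)(=O)c4cccc5cnccc45)cc3)CC2)cc1`, 109 nM

Compound 3 stands second highest of the three numbers; its nearest neighbour is compound 1, with a 1.4-fold higher number from compound 1 to compound 3 (0.15 log units; within the scatter), and its furthest is compound 2, with a 13-fold lower number from compound 2 to compound 3 (1.12 log units; beyond the scatter). Compound 4 `N#Cc1ccc(C(=O)N2CCC(n3cncc3-c3ccc(OS(=O)(=O)c4cccc5cnccc45)cc3)CC2)cc1` differs from compound 3 by cyano in place of 1-hydroxy-1-methylethyl on an aromatic carbon. Both earlier changes at this aromatic carbon bear on it: a 1.4-fold higher number from compound 1 to compound 3 (0.15 log units; within the scatter) shows two small uncharged groups interchangeable, whereas a 19-fold higher number from compound 1 to compound 2 (1.27 log units; beyond the scatter) shows the diethylamino group going with a much weaker number. Cyano, like methoxy, is a small uncharged group with one hydrogen-bond acceptor, so no step beyond the scatter is expected: a 1.1-fold higher number from compound 3 to compound 4 (0.04 log units; within the scatter). Compound 4 is estimated at 120 nM, range 40 nM to 400 nM.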

Compound 4, half-maximal inhibitory concentration: 269 nM
Compound 4: middle estimate off by 2.2-fold (0.35 log units), on the low side; low and high end bracket the measured number.
By their numbers in this assay, from the lowest: compounds 1 and 3 (each within the scatter of the next); then compound 4; then compound 2.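

At this aromatic carbon, para to a large group, cyano does not match the other uncharged groups in this assay: the series shows a 2.5-fold higher number from compound 3 to compound 4 (0.39 log units; beyond the scatter) and a 3.5-fold higher number from compound 1 to compound 4 (0.54 log units; beyond the scatter), both beyond the scatter, although compound 1 and compound 3 lie within the scatter of each other. Cyano still remains clear of diethylamino, with a 5.4-fold lower number from compound 2 to compound 4 (0.73 log units; beyond the scatter), so compound 4 occupies an intermediate place. Nothing available explains this separation.

Open, as far as these compounds go, is where a carboxylic acid, a primary amine or fluoro would fall at this carbon. Dimethylamino would test whether the loss seen with diethylamino extends to a smaller amine.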